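A few compounds are considered here, and "the series" means these few. Any claim that something is new, unique, unknown or untested is made for them only; others in the source may bear on it.

Measured so far in an ADME assay on CHO cells (Cricetulus griseus) for cytotoxicity, read by MTT assay; on this read-out higher numbers stand for lower toxicity in this test and lower numbers for higher toxicity in this test:
- Compound 1 `CN1CCN(C2CCN(c3nccc4[nH]c(-c5cc(F)cc(F)c5)nc34)CC2)CC1`: 30000 nM
- Compound 2 `CN1CCN(C2CCN(c3nccc4[nH]c(-c5cccc(C#N)c5)nc34)CC2)CC1`: 16000 nM

Compound 2, at 16000 nM, cannot be told apart from compound 1, at 30000 nM, since the gap between them lies within the usual scatter. With only these two numbers, neither compound can be called the more toxic in this assay.

The next compound, compound 3 `COC(=O)c1cccc(-c2nc3c(N4CCC(N5CCN(C)CC5)CC4)nccc3[nH]2)c1`, differs from compound 2 by one group: methoxycarbonyl in place of cyano on an aromatic carbon. In words, methoxycarbonyl stands in place of cyano on an aromatic carbon, meta to a large group.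

Going by the values given here, only one measured step bears on this change: a 1.9-fold lower number from compound 1 to compound 2 (0.27 log units; within the scatter). There, 3-cyanophenyl replaced 3,5-difluorophenyl, and the step stayed within the scatter. Among the compounds with values here, no measured compound carries methoxycarbonyl, so this is thin evidence, and no step beyond the scatter is expected in either direction.

The expected change is a 1.3-fold higher number from compound 2 to compound 3 (0.10 log units; within the scatter). For compound 3 the estimated value is 20000 nM, with an expected range of 8000 nM to 50000 nM.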

Compound 3, half-maximal cytotoxic concentration: 34000 nM
Compound 3: the middle estimate sits 1.7-fold (0.23 log units) below what was measured; measured number inside the range.
By their numbers in this assay, from the lowest: compounds 2, 1 and 3 (each within the scatter of the next, the first and the last beyond it).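

In this assay, going by these compounds alone, putting methoxycarbonyl in place of cyano on this aromatic carbon, meta to a large group, gives a 2.1-fold higher number from compound 2 to compound 3 (0.33 log units; beyond the scatter), and this is the only step among the three compounds that lies beyond the scatter, though only modestly. It shows that the group at this place can affect the number, which the earlier step could not show, and that methoxycarbonyl, with 4 heavy atoms against 2 in cyano, brings no sign of higher toxicity in this test than cyano. The comparison with the earlier ring gives a 1.1-fold higher number from compound 1 to compound 3 (0.05 log units; within the scatter), so 3-(methoxycarbonyl)phenyl and 3,5-difluorophenyl cannot be told apart here, and the gap seen for compound 3 depends on compound 2 alone.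

No measurement given here explains why this change moves the number. Still open, going by these compounds, is whether a carboxylic acid or an amide at this same place would give a number close to that of compound 3 or close to that of compound 2, and whether this single modest step would hold up with such groups.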